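A Smaller Sulfonyl Substituent on the Shared Core

The source may report more compounds than this note shows. Statements on the series, on what has been measured and on what is new or still open speak of the compounds shown alone.

Of the compounds shown here, three built on one shared core have been tested in a functional assay on SGC-7901 cells (Homo sapiens) for cytotoxicity, read by MTT assay, with a stated time of 48 h; a higher number here means a weaker inhibitor, a lower number a stronger inhibitor. Compound 1 `CCN(CC)c1ccc2cc(C(=O)c3ccc(N4CCN(C(=O)COc5ccc(Cl)cc5Cl)CC4)cc3)oc2c1` carries a ((2,4-dichlorophenoxy)methyl)carbonyl group on an amine nitrogen in a ring and gives 6170 nM in this assay. Compound 2 `CCN(CC)c1ccc2cc(C(=O)c3ccc(N4CCN(S(=O)(=O)c5ccc(F)cc5)CC4)cc3)oc2c1` has (4-fluorophenyl)sulfonyl in that place. In this assay compound 2 reaches only the limit of > 40000 nM, a boundary of the measurement rather than a number. Compound 3 `CCN(CC)c1ccc2cc(C(=O)c3ccc(N4CCN(S(=O)(=O)c5ccc(C)cc5)CC4)cc3)oc2c1` carries (4-methylphenyl)sulfonyl instead. Compound 3 likewise stops at the limit of > 40000 nM in this assay, again a limit and not a number. The step of an at least 6.4-fold higher number from compound 1 to compound 2 (0.81 log units; beyond the scatter) and the step of an at least 6.4-fold higher number from compound 1 to compound 3 (0.81 log units; beyond the scatter) run in the same direction, while the step that the two limits leave unreadable from compound 2 to compound 3 cannot be read because both of its ends sit at the limit of > 40000 nM in this assay, at which 2 of the 3 values shown sit. Compound 4 `CCN(CC)c1ccc2cc(C(=O)c3ccc(N4CCN(S(C)(=O)=O)CC4)cc3)oc2c1` is the next compound: methyl in place of 4-methylphenyl on a sulfonyl sulfur. For the measured compounds named here, compound 3 stands at the limit in this assay, and the two known sulfonyl steps point toward weak inhibition for sulfonyl groups here; no measured step tells how methyl on the sulfonyl sulfur compares with 4-methylphenyl. Compound 4 is therefore expected to remain at or near the limit, with an estimated 40000 nM in this assay, between 15000 nM and 120000 nM. The expected step of a number no higher from compound 3 to compound 4 (the limit leaves the size open) is accordingly none beyond the scatter.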

Compound 4, half-maximal inhibitory concentration: > 40000 nM
Compound 4: no number, only a limit; the forecaster's own chance of this, stated with the estimate: 75%; the middle value sits exactly at the limit.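

Cutting the group on the sulfonyl sulfur from 4-methylphenyl down to methyl removes the aromatic ring, yet in this assay compound 4 gives > 40000 nM, which is again a limit and not a number. The sulfonyl compounds shown now span 4-fluorophenyl, 4-methylphenyl and methyl on the sulfur, and with or without that ring none of them gives a readable value, while methylsulfonyl in place of ((2,4-dichlorophenoxy)methyl)carbonyl on the amine nitrogen in a ring gives an at least 6.4-fold higher number from compound 1 to compound 4 (0.81 log units; beyond the scatter). The steps among compound 2, compound 3 and compound 4 cannot be read, since all three stop at the same boundary: the limit of > 40000 nM in this assay, at which 3 of the 4 values shown sit.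

Going by these compounds, how these three sulfonyl compounds rank remains open, as does whether any other group on the sulfonyl sulfur, such as an amine or a longer carbon chain, would give a readable value. An acetyl group on the amine nitrogen in a ring would keep the carbonyl without the 2,4-dichlorophenoxy part, and could help show which portion of the group in compound 1 goes with its measurable value.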